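Butyl gives way to sec-butyl

This account rests on a few compounds, and the source may have more. Where it says the series, first, only, none or still open, it means among the compounds named here.

In a functional assay on the whole organism with Scenedesmus acutus as the target (a lower number here means a stronger inhibitor, a higher number a weaker inhibitor), compound 1 `O=C(O)c1cc(N2C(=O)C3=C(CCCC3)C2=O)c(F)cc1Cl` gives 759 nM, and compound 2 `CCCCOC(=O)c1cc(N2C(=O)C3=C(CCCC3)C2=O)c(F)cc1Cl` gives 67.6 nM, the lower of the two numbers. Among the measured compounds shown here, the only measured step, an 11-fold lower number from compound 1 to compound 2 (1.05 log units; beyond the scatter), is large, and it put butyl in place of hydrogen on an oxygen next to a carbonyl group. Compound 3 `CCC(C)OC(=O)c1cc(N2C(=O)C3=C(CCCC3)C2=O)c(F)cc1Cl` keeps the same atoms, with sec-butyl in place of butyl at that oxygen (sec-butyl in place of butyl on an oxygen next to a carbonyl group). For the measured compounds named here, no measured step compares two such chains, so no change beyond the scatter is expected. The expected step is a 1.2-fold higher number from compound 2 to compound 3 (0.07 log units; within the scatter). Compound 3 is estimated at 80 nM, with an expected range of 30 nM to 215 nM.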

Compound 3, half-maximal inhibitory concentration: 24.6 nM
Compound 3: the middle estimate sits 3.3-fold (0.51 log units) above what was measured; the measured number lies below the stated range.
By their numbers in this assay, from the lowest: compound 3; then compound 2; then compound 1.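

Branching alone counts at this oxygen next to a carbonyl group: in this assay, sec-butyl and butyl carry the same atoms, yet the rearranged chain gives a further gain beyond the scatter (a 2.7-fold lower number from compound 2 to compound 3 (0.44 log units; beyond the scatter)). The whole change from the free acid now reaches (a 31-fold lower number from compound 1 to compound 3 (1.49 log units; beyond the scatter)), so the size of the effect depends on the shape of the chain as well as on its presence. No evidence on hand accounts for this difference between the two chains. From the compounds shown here alone, whether isopropyl, tert-butyl or a longer branched chain would lower the number further remains open, as does whether an amide could stand in place of the ester.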